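Swapping fluoro for methoxy on a thiophene-carboxamide thiourea

The compounds below may be only part of what the source reports. "The series", "measured", "known", "first", "only" and "open" are said of these compounds alone.

Among the measured compounds shown here, compound 1 `NC(=O)c1c(NC(=O)c2ccccc2F)sc2c1CCN(C(=S)Nc1ccccc1Cl)C2` is one of two compounds measured in a functional assay on HL-60 cells (Homo sapiens) for antiproliferative activity, with a stated time of 24 h (a higher number here means a weaker inhibitor, a lower number a stronger inhibitor), and compound 1 gives 12500 nM, the lowest of the two numbers. Its partner, compound 2 `NC(=O)c1c(NC(=O)c2ccccc2F)sc2c1CCN(C(=O)Nc1ccccc1Cl)C2`, differs only at the ring amine, where a thiourea has become a urea; in this assay compound 2 gives 32700 nM. That single known step, a 2.6-fold higher number from compound 1 to compound 2 (0.42 log units; beyond the scatter), is a modest weakening and lies beyond the scatter.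

Compound 3 `COc1ccccc1C(=O)Nc1sc2c(c1C(N)=O)CCN(C(=S)Nc1ccccc1Cl)C2` keeps the thiourea of compound 1 and changes a different part of the molecule: methoxy in place of fluoro on an aromatic carbon. For the measured compounds named here, no measured pair touches this position, so the one known step, which concerns the ring amine, does not bear directly on it. With nothing shown for the benzamide ring, the safest expectation is a step within the scatter, in no firm direction, though a wide range is appropriate.

For compound 3 in this assay the estimate is 12500 nM, between 4000 nM and 40000 nM, which would mean an expected step of no change at the digits printed from compound 1 to compound 3 (within the scatter).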

Compound 3, half-maximal inhibitory concentration: 20800 nM
The estimate for compound 3 lay 1.7-fold (0.22 log units) below the measured number; the measured number falls inside the stated range.
By their numbers in this assay, from the lowest: compounds 1, 3 and 2 (each within the scatter of the next, the first and the last beyond it).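

The swap of fluoro for methoxy on an aromatic carbon, ortho to a large group, gives a 1.7-fold higher number from compound 1 to compound 3 (0.22 log units; within the scatter) in this assay. Among the compounds shown here, this is the first reading at this position, and it shows that compound 1 and compound 3 cannot be told apart here: with the thiourea kept, 2-fluorophenyl and 2-methoxyphenyl serve about equally well in this one comparison. No measurement shown gives any explanation for this result.

Groups such as hydroxy, amino or the longer ethoxy on this same carbon would show how far this tolerance extends, and an unsubstituted phenyl would show whether the position needs a group at all. Going by these compounds, it also remains open whether the methoxy would behave in the same way alongside the urea of compound 2, since the swap has so far been read only with the thiourea.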